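The source may hold more compounds than are shown below. What is called first, only, known or untested is meant among the compounds shown, and "the series" means these compounds.

Within the data shown here, compound 2 `COc1ncnc2c1c(-c1ccoc1)cn2[C@@H]1O[C@H](CO)[C@@H](O)[C@H]1O` carries a furan-3-yl group, and in a functional assay on CCRF-CEM cells (Homo sapiens), read by MTT assay, with a stated time of 72 h (on this read-out higher numbers stand for weaker inhibition and lower numbers for stronger inhibition), compound 2 gives 110 nM, the lowest of the two numbers measured so far. Among the measured compounds shown here, its nearest neighbour is compound 1 `COc1ncnc2c1c(-c1ccsc1)cn2[C@@H]1O[C@H](CO)[C@@H](O)[C@H]1O`, which in this assay gives 2570 nM; the step of a 23-fold lower number from compound 1 to compound 2 (1.37 log units; beyond the scatter) is the only measured step and concerns furan-3-yl in place of thiophen-3-yl on an aromatic carbon. Compound 3 `CSc1ncnc2c1c(-c1ccoc1)cn2[C@@H]1O[C@H](CO)[C@@H](O)[C@H]1O` has not yet been measured. It differs from compound 2 in one place: methylsulfanyl in place of methoxy on an aromatic carbon. For the measured compounds named here, no measured step touches the methoxy group or its place on the shared core, so the single step seen so far, from thiophen-3-yl to furan-3-yl, does not bear on this change and gives no direction for it. With nothing to guide the size, the expectation is a step in this assay within or close to the scatter, leaning toward a somewhat higher number, a 2.7-fold higher number from compound 2 to compound 3 (0.44 log units; beyond the scatter). Compound 3 is therefore estimated to give 300 nM in this assay, with a range from 60 nM to 1500 nM.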

Compound 3, half-maximal inhibitory concentration: 14200 nM
Compound 3: the middle estimate sits 47-fold (1.68 log units) below what was measured; measured number outside the range, above it.
By their numbers in this assay, from the lowest: compound 2; then compound 1; then compound 3.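

The place on the aromatic carbon that carries the methoxy group proved far from indifferent in this assay: methylsulfanyl in place of methoxy brought a 130-fold higher number from compound 2 to compound 3 (2.11 log units; beyond the scatter), a large step and the first measured at this position. The two groups match in their counts of heavy atoms and hydrogen-bond acceptors, carry no net charge and differ only in sulfur standing for oxygen, so a change that small on paper can decide most of the activity in this series. Together with a 23-fold lower number from compound 1 to compound 2 (1.37 log units; beyond the scatter), it means that in both measured steps the compound with oxygen gives the lower number and the one with sulfur the higher, a pattern resting on these three compounds alone, and nothing available explains the size of the new step.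

The compounds shown leave open how an amine, a methyl group or a longer chain such as ethoxy would read on this carbon, and so whether methoxy is a favoured group or methylsulfanyl a singularly poor one. They also leave open whether methylsulfanyl would cost as much alongside thiophen-3-yl as it does alongside furan-3-yl.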